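The source may hold more compounds than are shown below. What is called first, only, known or untested is meant among the compounds shown, and "the series" means these compounds.

Measured in an ADME assay on DU-145 cells (Homo sapiens) for cytotoxicity, read by MTT assay, with a stated time of 72 h; a lower number here means a stronger inhibitor, a higher number a weaker inhibitor:
- Compound 1 `COc1ccc(C2=C(c3cc(OC)c(OC)c(OC)c3)C(=O)C(O)C2)cc1`: > 100 ug/mL (a limit of the assay, not a number)
- Compound 2 `COc1ccc(C2=C(c3cc(OC)c(OC)c(OC)c3)C(=O)C(O[SiH2]C(C)(C)C)C2)cc1`: 28 ug/mL

Going by the values given here, on these results, compound 2 holds the only true number in this assay, as the other result is a limit. Compound 3 `COc1cc(C2=C(c3ccc(SC)cc3)CC(O[SiH2]C(C)(C)C)C2=O)cc(OC)c1OC` differs from compound 2 in one place: methylsulfanyl in place of methoxy on an aromatic carbon. In words, methylsulfanyl stands in place of methoxy on an aromatic carbon, para to a large group.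

Among the compounds with values here, only one measured step is available, an at least 3.5-fold lower number from compound 1 to compound 2 (0.55 log units; beyond the scatter). It starts from the limit of > 100 ug/mL in this assay, at which 1 of the 2 values shown sits. That change sits elsewhere, on an oxygen on a saturated carbon, so it shows that the number can move within this series but gives no size or direction for a change on the aromatic ring. Within the data shown here, with no measured step at this place, the expected change is a 1.1-fold lower number from compound 2 to compound 3 (0.05 log units; within the scatter), which means no shift beyond the scatter and no firm direction. The estimate for compound 3 is 25 ug/mL, with an expected range from 10 ug/mL to 65 ug/mL.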

Compound 3, half-maximal inhibitory concentration: > 100 ug/mL
Compound 3 gave a limit, no number; the forecaster's own chance of this, stated with the estimate: 10%; middle value at least 4.0-fold (0.60 log units) away from the limit.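

Putting methylsulfanyl in place of methoxy on this aromatic carbon, para to a large group, gives an at least 3.5-fold higher number from compound 2 to compound 3 (0.55 log units; beyond the scatter) in this assay. This position therefore responds to the change, even though the two groups match in their counts of heavy atoms and hydrogen-bond acceptors and differ mainly in carrying sulfur rather than oxygen. Compound 3 gives > 100 ug/mL, which is a limit of the assay and not a number. The step therefore sets only a minimum size, and the true gap may be larger, because the result stands at the edge of what the assay reports: the limit of > 100 ug/mL in this assay, at which 2 of the 3 values shown sit.

The compounds shown hold only methoxy and methylsulfanyl at this place, so it remains open whether another group there, such as an amine or a longer chain like ethoxy, would give a true number in this assay. From the compounds shown here alone, it is also open whether a group of this kind would give a number lower than that of compound 2, or whether methoxy is the better of the possible groups at this position.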